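Thiosemicarbazone series: aryl swap at the imine carbon

The source may hold more compounds than are shown below. What is called first, only, known or untested is meant among the compounds shown, and "the series" means these compounds.

Compound 2 `CC1=CC[C@H](C(C)(C)NC(=S)N/N=C/c2ccccc2O)CC1` holds the only number shown in a functional assay on 786-0 cells (Homo sapiens) for inhibition, read by sulforhodamine B assay, with a stated time of 48 h; a lower number here means a stronger inhibitor of growth, a higher number a weaker inhibitor of growth: compound 2 gives 4600 nM. Compound 1 `CC1=CC[C@H](C(C)(C)NC(=S)N/N=C/c2ccc(O)cc2)CC1` sits at the limit > 100000 nM in this assay, a limit rather than a number. The step of an at least 21-fold lower number from compound 1 to compound 2 (1.33 log units; beyond the scatter) is the only measured one and it bears on the 2-hydroxyphenyl. Compound 3 `CC1=CC[C@H](C(C)(C)NC(=S)N/N=C/c2ccc(F)cc2)CC1` differs from compound 2 by 4-fluorophenyl in place of 2-hydroxyphenyl on a carbon with a double bond to nitrogen. With the 2-hydroxyphenyl removed and a 4-substituted ring entering, a weaker inhibitor is expected, a step of a 6.5-fold higher number from compound 2 to compound 3 (0.81 log units; beyond the scatter). The estimate for compound 3 is 30000 nM, within 6000 nM to 150000 nM.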

Compound 3, concentration for 50% growth inhibition: > 100000 nM
Compound 3 was reported as a limit; the forecaster's own chance of this, stated with the estimate: 35%; middle value at least 3.3-fold (0.52 log units) from the limit.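

In this assay, replacing the hydroxy-bearing ring with 4-fluorophenyl gives an at least 21-fold higher number from compound 2 to compound 3 (1.33 log units; beyond the scatter), so the activity of compound 2 is not kept by this second 4-substituted ring. Among the three aryl groups on this carbon, only 2-hydroxyphenyl gives a number, and the other two stand at a limit: the limit of > 100000 nM in this assay, at which 2 of the 3 values shown sit. The step between compound 1 and compound 3 cannot be read, as both values are limits.

Open, as far as these compounds go, is how a plain phenyl, or a ring carrying methoxy or an amine, would read on this carbon. Also open, from the compounds shown here alone, is whether the hydroxy group itself or its place on the ring accounts for the number of compound 2.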